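Methyl for Fluoro Beside an Unchanging Flavone Core

The source may report more compounds than this note shows. Statements on the series, on what has been measured and on what is new or still open speak of the compounds shown alone.

Compound 1 `COC(=O)c1c(F)cccc1OC(=O)COc1cc(O)c2c(=O)cc(-c3ccccc3)oc2c1`: 40300 nM
Compound 2 `COC(=O)c1c(Br)cc(Br)cc1OC(=O)COc1cc(O)c2c(=O)cc(-c3ccccc3)oc2c1`: 45700 nM
Compound 3 `COC(=O)c1cccc(OC)c1OC(=O)COc1cc(O)c2c(=O)cc(-c3ccccc3)oc2c1`: 36800 nM

In a functional assay on cells (T-cell, Mus musculus, strain BALB/c) for inhibition, read by MTT assay, with a stated time of 72 h (on this read-out higher numbers stand for weaker inhibition and lower numbers for stronger inhibition), compound 1 gives 40300 nM, the second highest of the three numbers. Compound 3 gives 36800 nM and compound 2 gives 45700 nM; both lie within the scatter of compound 1, so no order among the three can be read. Compound 4 `COC(=O)c1c(C)cccc1OC(=O)COc1cc(O)c2c(=O)cc(-c3ccccc3)oc2c1` has not yet been measured in this assay. It differs from compound 1 by methyl in place of fluoro on an aromatic carbon. For the measured compounds named here, no step between measured compounds is available, and all three measured numbers sit within the scatter of one another, so nothing here points in either direction. The expected step of a 1.0-fold lower number from compound 1 to compound 4 (0.00 log units; within the scatter) is therefore none beyond the scatter. Compound 4 is estimated at 40000 nM, with a range from 20000 nM to 80000 nM in this assay.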

Compound 4, half-maximal inhibitory concentration: 37200 nM
For compound 4 the middle estimate is 1.1-fold (0.03 log units) above the measured one; the range from low to high includes it.
By their numbers in this assay, from the lowest: compounds 3, 4, 1 and 2 (each within the scatter of the next).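

In this assay, for the compounds shown here, methyl in place of fluoro gives a 1.1-fold lower number from compound 1 to compound 4 (0.03 log units; within the scatter) within the scatter, the first step at this position, which is ortho to a methoxycarbonyl group. Going by these compounds alone, the two groups therefore cannot be told apart on this read-out, a result the earlier compounds, which differ in more than one place, could not give. No available evidence bears on this result. Going by these compounds, whether an amine, a carboxylic acid or a longer chain on this aromatic carbon would give a step beyond the scatter remains open.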